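Carbamate nitrogen swaps and maximal response at the urotensin receptor

The source may report more compounds than this note shows. Statements on the series, on what has been measured and on what is new or still open speak of the compounds shown alone.

Two carbamates sharing one core have been measured in an assay on NIH3T3 cells with Urotensin-2 receptor (Homo sapiens) as the target; on this read-out higher numbers stand for larger maximal responses and lower numbers for smaller maximal responses. Compound 1 `Cc1ccccc1NC(=O)OC(CCN(C)C)c1ccc(Cl)cc1` carries a 2-methylphenyl group on the amide-type nitrogen and in this assay compound 1 gives 176%. Compound 2 `CN(C)CCC(OC(=O)NCc1ccccc1)c1ccc(Cl)cc1` carries a benzyl group there instead, and in this assay compound 2 gives 180%. For the measured compounds named here, the only step measured so far, a number 4 percentage points higher from compound 1 to compound 2 (within the scatter), shows that exchanging one of these groups for the other leaves the maximal response essentially unchanged. Among the two numbers compound 2 stands highest, but its distance to compound 1 is within the scatter, so the two are best seen as alike.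

Compound 3 `COc1cccc(NC(=O)OC(CCN(C)C)c2ccc(Cl)cc2)c1` has not yet been measured. It differs from compound 2 by 3-methoxyphenyl in place of benzyl on an amide-type nitrogen. Going by the values given here, the one measured step bears on this: it also altered the group on the amide-type nitrogen, moving from an aromatic ring attached directly to a ring carried on a one-carbon linker, with no change beyond the scatter. For compound 3 the step of a number 4 percentage points lower from compound 2 to compound 3 (within the scatter) is therefore expected to stay within the scatter. In this assay compound 3 is estimated at 176%, with a range from 150% to 200%.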

Compound 3, largest response reached (reported as efficacy), in percent of the reference or control that the assay uses: 136%
Beside the measured number, compound 3's estimate is 40 percentage points above it, and the stated range ends above it.
By their numbers in this assay, from the lowest: compound 3; then compounds 1 and 2 (each within the scatter of the next).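

The group on the amide-type nitrogen is not as freely exchangeable as the first two compounds suggested: in this assay there is a number 44 percentage points lower from compound 2 to compound 3 (beyond the scatter), so this change does alter the maximal response. Direct attachment of an aromatic ring to the nitrogen cannot by itself set the level, since compound 1 has such a ring too, and there is still a number 40 percentage points lower from compound 1 to compound 3 (beyond the scatter); compound 3 therefore stands lowest of the three, and the outcome depends on what the ring carries. The 3-methoxyphenyl group brings an oxygen and a hydrogen-bond acceptor that benzyl lacks, but no measurement here links either feature to the drop, and no supporting evidence is available to explain it.

Compound 1 and compound 3 differ in both the substituent and its place on the ring, so these compounds cannot show which of the two matters. A plain phenyl group, a hydroxyl in place of the methoxy group, or a longer chain between the nitrogen and the ring would each test a different part of this question.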